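A Morpholinylcarbonyl Group in Place of Phenyl: What to Expect

The source may report more compounds than this note shows. Statements on the series, on what has been measured and on what is new or still open speak of the compounds shown alone.

In an assay on isolated protein for inhibition of DNA nucleotidylexotransferase (Homo sapiens), read by scintillation counting, with a stated time of 10 min (on this read-out higher numbers stand for weaker inhibition and lower numbers for stronger inhibition), compound 2 `CCOC(=O)C(=O)CC(=O)/C=C/c1cn(Cc2ccccc2)c2ccccc12` gives > 40 uM, which is a limit of the assay and not a number. Compound 1 `CCOC(=O)C(=O)CC(=O)/C=C/c1cn(C=C(C)C)c2ccccc12` likewise gives > 40 uM, again a limit. The step that the two limits leave unreadable from compound 1 to compound 2 therefore stays unreadable because both values sit at the limit of > 40 uM in this assay, at which 2 of the 2 values shown sit. Compound 3 `CCOC(=O)C(=O)CC(=O)/C=C/c1cn(CC(=O)N2CCOCC2)c2ccccc12` differs from compound 2 in one place: (morpholin-4-yl)carbonyl in place of phenyl on a saturated chain carbon bound to an aromatic nitrogen. The shared core and the chain attached to it are untouched. Within the data shown here, no measured step bears directly on this exchange, and the single comparison on record tells nothing about size or direction. With both known values resting at the limit, there is no ground for expecting a change beyond the scatter, so the expected step that the limit leaves unreadable from compound 2 to compound 3 is small. Compound 3 is estimated at 60 uM, within a range from 20 uM to 200 uM, most probably reported once more as a limit.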

Compound 3, concentration for 50% inhibition: > 40 uM
Compound 3: no number, only a limit; the forecaster's own chance of this, stated with the estimate: 85%; the middle value does not contradict the limit.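

No step can be read between compound 1, compound 2 and compound 3, because in this assay all three stop at the same limit and give no number: the limit of > 40 uM in this assay, at which 3 of the 3 values shown sit.

The compounds shown leave open how strongly each one truly inhibits, and whether exchanging the group on the aromatic nitrogen changes that at all.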